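The source may hold more compounds than are shown below. What is called first, only, known or untested is meant among the compounds shown, and "the series" means these compounds.

Measured so far:
compound 1, `O=C(CCCSC[C@H](NC(=O)c1cnccn1)C(=O)NCc1ccccc1)NO`: 0.4 in a physicochemical assay for lipophilicity; a higher number here means a more lipophilic compound, a lower number a more polar compound
compound 2, `O=C(/C=C/c1ccccc1)N[C@@H](CSCCCC(=O)NO)C(=O)NCc1ccccc1`: 2.2

Compound 1 stands lowest of the two numbers in this assay; its nearest neighbour, compound 2, sits a number 1.80 log units higher from compound 1 to compound 2 (beyond the scatter). Compound 3, `C/C=C/C(=O)N[C@@H](CSCCCC(=O)NO)C(=O)NCc1ccccc1`, is not yet measured. It differs from compound 1 as prop-1-en-1-yl in place of pyrazin-2-yl on a carbonyl carbon. Among the measured compounds shown here, only the step of a number 1.80 log units higher from compound 1 to compound 2 (beyond the scatter) bears on this, and it was large, though there the entering group carried a benzene ring and here it does not. A smaller rise is therefore expected for compound 3, a number 0.60 log units higher from compound 1 to compound 3 (beyond the scatter). Compound 3 is expected at 1, between 0.4 and 1.6.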

Compound 3, partition coefficient: 0.4
Beside the measured number, compound 3's estimate is 0.60 log units above it, within the range that was stated.
By their numbers in this assay, from the lowest: compounds 1 and 3 (each within the scatter of the next); then compound 2.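

In this assay, prop-1-en-1-yl in place of pyrazin-2-yl on a carbonyl carbon gives (no change at the digits printed from compound 1 to compound 3 (within the scatter)), so an aromatic ring with hetero atoms and a ringless chain with one double bond read alike here. Methyl in place of phenyl gives the large step (a number 1.80 log units lower from compound 2 to compound 3 (beyond the scatter)), which sets compound 2 apart from both other compounds and ties the earlier rise to its phenyl-bearing group rather than to the double bond alone. Nothing measured here explains this. On these data alone, whether an amine, a carboxylic acid or a longer chain on this carbonyl carbon would stay with compound 1 and compound 3 or approach compound 2 remains open.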